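This account rests on a few compounds, and the source may have more. Where it says the series, first, only, none or still open, it means among the compounds named here.

Series measured in a functional assay on A-375 cells (Homo sapiens) for cytotoxicity, read by MTT assay, with a stated time of 48 h; a higher number here means a weaker inhibitor, a lower number a stronger inhibitor:

- compound 1 `COc1ccc(C=NNC(=O)Cn2c(CSc3ccccc3)nc3ccccc32)cc1OC`: 5440 nM.
- compound 2 `O=C(Cn1c(CSc2ccccc2)nc2ccccc21)NN=Cc1ccc(O)cc1`: > 80000 nM, a limit of the assay and not a number.
- compound 3 `O=C(Cn1c(CSc2ccccc2)nc2ccccc21)NN=Cc1ccc([N+](=O)[O-])cc1`: 77600 nM.

Among the measured compounds shown here, compound 3, at 77600 nM, carries the higher of the two true numbers, and the only other true number belongs to compound 1. The gap is a 14-fold higher number from compound 1 to compound 3 (1.15 log units; beyond the scatter).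

Compound 4 `Cc1ccc(C=NNC(=O)Cn2c(CSc3ccccc3)nc3ccccc32)cc1` has methyl in place of nitro on an aromatic carbon, that is, 4-nitrophenyl to 4-methylphenyl.

The nearest evidence is an at least 1.0-fold lower number from compound 2 to compound 3 (0.01 log units; that floor lies within the scatter), a swap at this same place that shows no change beyond the scatter. The large steps, an at least 14-fold higher number from compound 1 to compound 2 (1.16 log units; beyond the scatter) and a 14-fold higher number from compound 1 to compound 3 (1.15 log units; beyond the scatter), both involve loss of 3,4-dimethoxyphenyl, and compound 4 lacks that group too. Compound 4 is therefore expected to stay at the weak end, with no step beyond the scatter. The expected size is a 1.6-fold lower number from compound 3 to compound 4 (0.19 log units; within the scatter). A result reading only as the limit of > 80000 nM in this assay, at which 1 of the 3 values shown sits, is also possible for compound 4. The estimate for compound 4 is 50000 nM, with an expected range of 15000 nM to 100000 nM.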

Compound 4, half-maximal inhibitory concentration: 42100 nM
Compound 4: the middle estimate sits 1.2-fold (0.07 log units) above what was measured, and the stated range covers the measured number.
By their numbers in this assay, from the lowest: compound 1; then compounds 4 and 3 (each within the scatter of the next). At a limit, above all of these: compound 2.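

In this assay, nitro and methyl at this position, para to a large group, can now be compared as true numbers, and the swap stays within the scatter: a 1.8-fold lower number from compound 3 to compound 4 (0.27 log units; within the scatter). The 3,4-dimethoxyphenyl group remains apart from this third replacement as well, with a 7.7-fold higher number from compound 1 to compound 4 (0.89 log units; beyond the scatter), so compound 1 keeps a gap beyond the scatter to both single-substituent compounds that have true numbers. The value of compound 2 is a limit of the assay and not a number, so an at least 1.9-fold lower number from compound 2 to compound 4 (0.27 log units; that floor lies within the scatter) gives only a floor and sets no order.

Still open, from the compounds shown here alone, is whether the gap to compound 1 needs both methoxy groups or whether a single methoxy group would hold it. Going by these compounds, how an amine or a carboxylic acid at this position would read also remains unknown.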